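The source may report more compounds than this note shows. Statements on the series, on what has been measured and on what is new or still open speak of the compounds shown alone.

Among the measured compounds shown here, compound 3 `CCOc1ccc(C(=O)/C=C/c2c(/C=C/c3ccc(OC)cc3)cc(OC)cc2OC)cc1` has the lowest number of the three measured so far in a functional assay on HepG2 cells (Homo sapiens) for antiproliferative activity, read by MTT assay, with a stated time of 48 h (a lower number here means a stronger inhibitor, a higher number a weaker inhibitor), where compound 3 gives 8 ug/mL. Compound 1 `COc1ccc(/C=C/c2cc(OC)cc(OC)c2/C=C/C(=O)c2cccc(OC)c2)cc1` gives 11.6 ug/mL in this assay, and compound 2 `CCCCCCOc1ccc(C(=O)/C=C/c2c(/C=C/c3ccc(OC)cc3)cc(OC)cc2OC)cc1` gives 16.2 ug/mL. The step of a 1.5-fold lower number from compound 1 to compound 3 (0.16 log units; within the scatter) stays within the scatter, so compounds 1 and 3 cannot be told apart, whereas the step of a 2.0-fold lower number from compound 2 to compound 3 (0.31 log units; beyond the scatter) is a modest one. Compound 4 `COc1ccc(/C=C/c2cc(OC)cc(OC)c2/C=C/C(=O)c2ccc(-c3ccccc3)cc2)cc1` differs from compound 3 by phenyl in place of ethoxy on an aromatic carbon. For the measured compounds named here, of the measured steps, only the one from compound 2 to compound 3 bears on this change: there too the size of the group on that ring changed, and the larger group carried the higher number. A modest rise is therefore expected, a 1.8-fold higher number from compound 3 to compound 4 (0.24 log units; within the scatter). Compound 4 is estimated at 14 ug/mL, within 7 ug/mL to 28 ug/mL.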

Compound 4, half-maximal inhibitory concentration: 10.5 ug/mL
Beside the measured number, compound 4's estimate is 1.3-fold (0.12 log units) above it; low and high end bracket the measured number.
By their numbers in this assay, from the lowest: compounds 3, 4, 1 and 2 (each within the scatter of the next, the first and the last beyond it).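

In this assay, a phenyl ring on this aromatic carbon cannot be told apart from ethoxy (a 1.3-fold higher number from compound 3 to compound 4 (0.12 log units; within the scatter)). Phenyl also stays within the scatter of hexyloxy (a 1.5-fold lower number from compound 2 to compound 4 (0.19 log units; within the scatter)), and 4-phenylphenyl of 3-methoxyphenyl (a 1.1-fold lower number from compound 1 to compound 4 (0.04 log units; within the scatter)), so the higher number seen with the larger hexyloxy chain does not carry over to this larger ring. No measurement shown accounts for this result. Still open, as far as these compounds go, is whether an amine or a carboxylic acid at this place would move the number beyond the scatter.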